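Chloro in place of fluoro: expectation for compound 3

The compounds below may be only part of what the source reports. "The series", "measured", "known", "first", "only" and "open" are said of these compounds alone.

Two members of the series have numbers in a functional assay on HepG2 cells (Homo sapiens) for antiproliferative activity, read by MTT assay, with a stated time of 48 h; on this read-out higher numbers stand for weaker inhibition and lower numbers for stronger inhibition. Compound 1 `O=C(/C=C/c1ccccc1)Nc1cc2ncnc(Nc3cc(Cl)cc(Cl)c3)c2s1` gives 10700 nM in this assay. Compound 2 `O=C(/C=C/c1ccccc1)Nc1cc2c(Nc3ccc(F)c(Cl)c3)ncnc2s1` gives 22800 nM, the highest of the two numbers; its gap to compound 1 lies beyond the scatter, so compound 2 is the weaker inhibitor of the pair. Compound 3 `O=C(/C=C/c1ccccc1)Nc1cc2c(Nc3ccc(Cl)c(Cl)c3)ncnc2s1` is not yet measured. It differs from compound 2 by chloro in place of fluoro on an aromatic carbon; cut one bond further out, the change reads 3-chloro-4-fluorophenyl to 3,4-dichlorophenyl. Among the compounds with values here, no measured pair differs in a single place, so nothing here sizes this change directly. Compound 1 carries two chloro groups on that ring and sits in the weak range, so compound 3 is expected to stay there too. The expected step is a 1.8-fold lower number from compound 2 to compound 3 (0.24 log units; within the scatter), a modest move toward stronger inhibition near the edge of the scatter. Compound 3 is thus estimated at 13000 nM, within 5000 nM to 35000 nM.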

Compound 3, half-maximal inhibitory concentration: 30100 nM
Estimate against measurement, compound 3: 2.3-fold (0.36 log units) below; measured number inside the range.
By their numbers in this assay, from the lowest: compound 1; then compounds 2 and 3 (each within the scatter of the next).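

In this assay, within the data shown here, the change from 3-chloro-4-fluorophenyl to 3,4-dichlorophenyl gives a 1.3-fold higher number from compound 2 to compound 3 (0.12 log units; within the scatter), the first step that isolates a single place. At this position, para to a large group and ortho to a chloro group, chloro in place of fluoro therefore leaves two numbers that cannot be told apart, though this rests on one pair only. The data on hand give no reason for this outcome.

From the compounds shown here alone, whether any group at this position can move the number beyond the scatter stays open; a methoxy group, a nitrile or plain hydrogen there would test that. Going by these compounds, compound 1 differs from compound 2 and compound 3 in more than one place, so what sets it apart from them also stays open.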